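Swapping the aryl group on a shared core

The compounds below may be only part of what the source reports. "The series", "measured", "known", "first", "only" and "open" are said of these compounds alone.

Compound 1 `Nc1nc(N/N=C/c2ccc(N(c3ccccc3)c3ccccc3)cc2)nc2c1ncn2[C@@H]1O[C@H](CO)[C@@H](O)[C@H]1O` gives 0% in an assay on CHO-K1 cells for displacement of a labelled ligand from adenosine receptor A1 (Homo sapiens), read by scintillation counting, with a stated time of 60 min, tested at 1 uM; on this read-out lower numbers stand for less inhibition and higher numbers for more inhibition at the one concentration tested (going by the name of the read-out).
Compound 2 `Nc1nc(N/N=C/c2ccc(Cl)c(C(F)(F)F)c2)nc2c1ncn2[C@@H]1O[C@H](CO)[C@@H](O)[C@H]1O` gives 11% in this assay.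
Compound 3 `Nc1nc(N/N=C/c2ccc(C(F)(F)F)cc2C(F)(F)F)nc2c1ncn2[C@@H]1O[C@H](CO)[C@@H](O)[C@H]1O` gives 0% in this assay.

Compound 2 stands highest of the three numbers; compound 1 and compound 3 both sit lower by a gap beyond the usual scatter, so the whole set stays near the floor of the read-out. Compound 4 `CCCOc1ccc(/C=N/Nc2nc(N)c3ncn([C@@H]4O[C@H](CO)[C@@H](O)[C@H]4O)c3n2)cc1` differs from compound 2 by one change: 4-propoxyphenyl in place of 4-chloro-3-(trifluoromethyl)phenyl on a carbon with a double bond to nitrogen. Among the measured compounds shown here, no pair of measured compounds isolates this change, so its effect is unknown. Given that all three measured values are small, the step of a number 6 percentage points lower from compound 2 to compound 4 (within the scatter) is expected to be small, downward or none beyond the scatter. Compound 4 is therefore estimated at 5%, with a likely range from 0% to 20%.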

Compound 4, a percentage reported as inhibition, at one concentration (the size of the read-out at that concentration, not a potency): 7%
Estimate against measurement, compound 4: 2 percentage points below, within the range that was stated.
By their numbers in this assay, from the lowest: compounds 1, 3, 4 and 2 (each within the scatter of the next, the first and the last beyond it).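

In this assay, putting 4-propoxyphenyl in place of 4-chloro-3-(trifluoromethyl)phenyl on the carbon with a double bond to nitrogen gives a number 4 percentage points lower from compound 2 to compound 4 (within the scatter). Among the compounds shown here, this is the first single change read at this position, and it shows that an aryl group with an oxygen-linked propyl chain and no halogen leaves the number near the floor of the read-out. Nothing available explains this outcome. The compounds shown leave open whether a longer alkoxy chain, an amine or a carboxylic acid on this aryl ring would move the number beyond the scatter.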